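The source may report more compounds than this note shows. Statements on the series, on what has been measured and on what is new or still open speak of the compounds shown alone.

In a functional assay on Bel7402/5-FU cells (Homo sapiens) for antiproliferative activity, read by MTT assay, with a stated time of 72 h (a lower number here means a stronger inhibitor, a higher number a weaker inhibitor), three compounds have been measured:

Compound 1 `C=C1C(=O)O[C@H]2[C@H]1CC/C(COC(=O)Cn1cc(F)c(=O)n(Cc3ccc(Br)cc3)c1=O)=C\CC[C@@]1(C)O[C@@H]21` gives 3240 nM
Compound 2 `C=C1C(=O)O[C@H]2[C@H]1CC/C(COC(=O)Cn1cc(F)c(=O)n(Cc3cccc(F)c3)c1=O)=C\CC[C@@]1(C)O[C@@H]21` gives 3700 nM
Compound 3 `C=C1C(=O)O[C@H]2[C@H]1CC/C(COC(=O)Cn1cc(F)c(=O)n(Cc3c(F)cccc3F)c1=O)=C\CC[C@@]1(C)O[C@@H]21` gives 4980 nM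

Compound 3 cannot be separated from the other two, as the steps of a 1.5-fold higher number from compound 1 to compound 3 (0.19 log units; within the scatter) and a 1.3-fold higher number from compound 2 to compound 3 (0.13 log units; within the scatter) both lie within the scatter. Compound 4 `C=C1C(=O)O[C@H]2[C@H]1CC/C(COC(=O)Cn1cc(F)c(=O)n(Cc3ccc(F)c(F)c3)c1=O)=C\CC[C@@]1(C)O[C@@H]21` carries 3,4-difluorophenyl in place of 2,6-difluorophenyl on a saturated chain carbon bound to an aromatic nitrogen, with the same atoms joined differently. The closest evidence is those two steps and a 1.1-fold higher number from compound 1 to compound 2 (0.06 log units; within the scatter), which also stays within the scatter. No shift beyond the scatter is therefore expected in this assay, and the estimated step, a 1.3-fold lower number from compound 3 to compound 4 (0.11 log units; within the scatter), has no firm direction. For compound 4 the estimated value is 3900 nM, with an expected range of 2100 nM to 7000 nM.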

Compound 4, half-maximal inhibitory concentration: 4480 nM
Beside the measured number, compound 4's estimate is 1.1-fold (0.06 log units) below it; the range from low to high includes it.
By their numbers in this assay, from the lowest: compounds 1, 2, 4 and 3 (each within the scatter of the next).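

In this assay, the second fluorine arrangement at this position gives no separation: 3,4-difluorophenyl in place of 2,6-difluorophenyl stays within the scatter (a 1.1-fold lower number from compound 3 to compound 4 (0.05 log units; within the scatter)). Adding fluoro to an aromatic carbon of the 3-fluorophenyl group (a 1.2-fold higher number from compound 2 to compound 4 (0.08 log units; within the scatter)) and replacing 4-bromophenyl (a 1.4-fold higher number from compound 1 to compound 4 (0.14 log units; within the scatter)) also stay within it, so all four phenyl variants remain unresolved from one another. No evidence on the cause of this is available here. Still open, as far as these compounds go, is whether an amine or a carboxylic acid on the phenyl group, or a longer chain in place of the saturated chain carbon, would shift the number beyond the scatter.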